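Removing the dimethylamino group from a bis-benzylidene cyclohexanone

This account rests on a few compounds, and the source may have more. Where it says the series, first, only, none or still open, it means among the compounds named here.

Measured compounds:
- compound 1, `COc1ccc(/C=C2\CCC/C(=C\c3ccc([N+](=O)[O-])cc3)C2=O)cc1`: 250000 nM
- compound 2, `CN(C)c1ccc(/C=C2\CCC/C(=C\c3ccccc3[N+](=O)[O-])C2=O)cc1`: 168000 nM
- compound 3, `O=C1/C(=C/c2ccc(Cl)cc2)CCC/C1=C\c1cccc([N+](=O)[O-])c1`: 1750 nM

All three were tested in a functional assay on CCRF-CEM cells (Homo sapiens) for cytotoxicity, with a stated time of 72 h; a higher number here means a weaker inhibitor, a lower number a stronger inhibitor. Among them compound 2 stands at the second highest number; its nearest neighbour is compound 1, whose value lies within the scatter of that of compound 2, while compound 3 sits far below both, beyond the scatter. The unmeasured compound 4, `O=C1/C(=C/c2ccccc2)CCC/C1=C\c1ccccc1[N+](=O)[O-]`, keeps the core of compound 2 and differs from it in one place: hydrogen in place of dimethylamino on an aromatic carbon. For the measured compounds named here, no measured pair shows a step of this kind, so the direction is open. For compound 4 a moderate move toward a lower number in this assay is expected, a 3.4-fold lower number from compound 2 to compound 4 (0.53 log units; beyond the scatter), with wide uncertainty. Compound 4 is thus estimated at 50000 nM, in the range 8000 nM to 300000 nM.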

Compound 4, half-maximal inhibitory concentration in the CCRF-CEM assay: 925 nM
The estimate for compound 4 lay 54-fold (1.73 log units) above the measured number; measured number below the stated range.
By their numbers in the CCRF-CEM assay, from the lowest: compounds 4 and 3 (each within the scatter of the next); then compounds 2 and 1 (each within the scatter of the next).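

For the compounds shown here, replacing dimethylamino with hydrogen on this aromatic carbon gives in the CCRF-CEM assay a 180-fold lower number from compound 2 to compound 4 (2.26 log units; beyond the scatter), the first single-place step here, so this position bears strongly on the cytotoxicity read-out. In a physicochemical assay for lipophilicity (on this read-out higher numbers stand for higher lipophilicity and lower numbers for lower lipophilicity), compound 2 gives 4.86 and compound 4 gives 4.86, so the large step in cytotoxicity comes without any difference in this read-out. Nothing shown explains the step. Going by these compounds, it remains open whether a primary amine or a carboxylic acid at this place would keep the number of compound 4 or move it toward that of compound 2.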